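Removing the chloro from the anilino ring of compound 2

This account rests on a few compounds, and the source may have more. Where it says the series, first, only, none or still open, it means among the compounds named here.

Measured compounds in a functional assay on HCT-116 cells (Homo sapiens) for antiproliferative activity, read by CCK-8 assay, with a stated time of 72 h, tested at 8 uM; on this read-out lower numbers stand for a weaker effect and higher numbers for a stronger effect at the one concentration tested:
- compound 1 `CCCCn1cnc2c(Nc3cccc(Cl)c3)nc(NCOCc3ccc(/C=C/C(=O)Nc4ccccc4N)cc3)nc21` gives 10.9%
- compound 2 `Nc1ccccc1NC(=O)/C=C/c1ccc(COCNc2nc(Nc3cccc(Cl)c3)c3ncn(C4CCCC4)c3n2)cc1` gives 9.19%
- compound 3 `CC(C)n1cnc2c(Nc3cccc(Cl)c3)nc(NCOCc3ccc(/C=C/C(=O)Nc4ccccc4N)cc3)nc21` gives 27.9%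

Of these three numbers, that of compound 2 is the lowest, though the nearest gap is only a number 1.7 percentage points lower from compound 1 to compound 2 (within the scatter) and so within the scatter; the one gap that is beyond the scatter is a number 18.7 percentage points higher from compound 2 to compound 3 (beyond the scatter), and compound 1 shows the same in a number 17 percentage points higher from compound 1 to compound 3 (beyond the scatter). All three measured steps change the group on the aromatic nitrogen of the shared core and leave the rest untouched.

Compound 4 `Nc1ccccc1NC(=O)/C=C/c1ccc(COCNc2nc(Nc3ccccc3)c3ncn(C4CCCC4)c3n2)cc1` takes a different path from compound 2: hydrogen in place of chloro on an aromatic carbon. For the measured compounds named here, the anilino ring is nowhere varied among compounds 1, 2 and 3, so no measured step bears on this change, and the number measured for compound 2 is the only anchor. In the absence of any step of the same kind, the expectation for compound 4 in this assay is a step of about a number 0.2 percentage points lower from compound 2 to compound 4 (within the scatter), that is, nothing beyond the scatter in either direction. Compound 4 is therefore estimated at 9%, with a range from 0% to 22%.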

Compound 4, a percentage reported as inhibition, at one concentration (the size of the read-out at that concentration, not a potency): 17.3%
Estimate against measurement, compound 4: 8.3 percentage points below; the measured number falls inside the stated range.
By their numbers in this assay, from the lowest: compounds 2, 1 and 4 (each within the scatter of the next); then compound 3.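

In this assay, the change from 3-chlorophenyl to phenyl, made with the cyclopentyl group on the aromatic nitrogen kept in place, gives a number 8.1 percentage points higher from compound 2 to compound 4 (within the scatter). This is the only step shown away from the group on the aromatic nitrogen, and it indicates that, at this one concentration, the read-out can tolerate losing this single chlorine atom from an aromatic carbon meta to a large group without moving beyond the usual scatter, whereas the steps from butyl or cyclopentyl to isopropyl on the aromatic nitrogen do go beyond it. No measurement is available that would explain this step or assign any property to the chloro.

The compounds shown leave open whether the same change would read the same way with butyl or isopropyl on the aromatic nitrogen, as the pair compared here carries cyclopentyl alone. They also leave open how a fluoro, methoxy or trifluoromethyl group on this same aromatic carbon would read against the chloro and the hydrogen.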